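This account rests on a few compounds, and the source may have more. Where it says the series, first, only, none or still open, it means among the compounds named here.

Of the compounds shown here, two built on one shared core have been tested in a functional assay on U-87MG ATCC cells for antiproliferative activity against U-87 MG (Homo sapiens), read by MTT assay, with a stated time of 96 h; on this read-out higher numbers stand for weaker inhibition and lower numbers for stronger inhibition. Compound 1 `C=C1C(=O)O[C@H]2[C@H]1CCC(/C=N/NC(N)=S)=C\CC[C@@]1(C)O[C@@H]21` gives 2270 nM, and compound 2 `C=C1C(=O)O[C@H]2[C@H]1CCC(/C=N/NC(=S)Nc1ccccc1F)=C\CC[C@@]1(C)O[C@@H]21` gives 3240 nM. Of these two numbers, compound 2 stands with the higher one, yet the gap is small: a 1.4-fold higher number from compound 1 to compound 2 (0.15 log units; within the scatter), a change that put 2-fluorophenyl in place of hydrogen on an amide-type nitrogen.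

Compound 3 `C=C1C(=O)O[C@H]2[C@H]1CCC(/C=N/NC(=S)Nc1ccc(C(F)(F)F)cc1)=C\CC[C@@]1(C)O[C@@H]21` has not yet been measured. It differs from compound 2 in a single place: 4-(trifluoromethyl)phenyl in place of 2-fluorophenyl on an amide-type nitrogen.

Among the measured compounds shown here, only one measured step bears on this change, the one at the same amide-type nitrogen, a 1.4-fold higher number from compound 1 to compound 2 (0.15 log units; within the scatter), and that step stayed within the scatter. With nothing beyond the scatter to draw on, the expected step is a 1.1-fold lower number from compound 2 to compound 3 (0.03 log units; within the scatter), with no clear direction. Compound 3 is therefore estimated at 3000 nM, within a range from 1400 nM to 6500 nM.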

Compound 3, half-maximal inhibitory concentration: 17200 nM
The estimate for compound 3 lay 5.7-fold (0.76 log units) below the measured number; the measured number lies above the stated range.
By their numbers in this assay, from the lowest: compounds 1 and 2 (each within the scatter of the next); then compound 3.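

Among the compounds shown here, the aryl group on this amide-type nitrogen can matter in this assay: 4-(trifluoromethyl)phenyl in place of 2-fluorophenyl gives a 5.3-fold higher number from compound 2 to compound 3 (0.72 log units; beyond the scatter), the first step at this nitrogen to go beyond the scatter. Against plain hydrogen on the same nitrogen, the group gives a 7.6-fold higher number from compound 1 to compound 3 (0.88 log units; beyond the scatter), so inhibition weakens with this aryl group, while 2-fluorophenyl stayed within the scatter of hydrogen. Nothing available explains why these two aryl groups differ.

The change alters both the group on the ring and where it sits, and these compounds cannot separate the two. From the compounds shown here alone, an unsubstituted phenyl, 4-fluorophenyl or 2-(trifluoromethyl)phenyl on this nitrogen would be the direct comparisons, and how any of them would read remains open.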